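Replacing 3,4-dichlorophenyl on the bromo-bearing compound 3

The compounds below may be only part of what the source reports. "The series", "measured", "known", "first", "only" and "open" are said of these compounds alone.

Going by the values given here, in a functional assay on SW-620 cells (Homo sapiens) (a higher number here means a weaker inhibitor of growth, a lower number a stronger inhibitor of growth), compound 3 (`O=S(=O)(/C=C/c1ccc(Cl)c(Cl)c1)Cc1ccc(Nc2ncnc3ccc(Br)cc23)cc1`) gives 5000 nM, the lowest of the two actual numbers so far. Compound 1 (`O=S(=O)(/C=C/c1ccc(Cl)c(Cl)c1)Cc1ccc(Nc2ncnc3ccccc23)cc1`) gives 41000 nM. Bromo in place of hydrogen on an aromatic carbon accounts for the structural difference behind an 8.2-fold lower number from compound 1 to compound 3 (0.91 log units; beyond the scatter). Compound 2 (`O=S(=O)(/C=C/c1ccc(Br)cc1)Cc1ccc(Nc2ncnc3ccccc23)cc1`) is recorded at > 100000 nM, which is a limit of the assay and not a number.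

Compound 4 (`O=S(=O)(/C=C/c1ccc(Br)cc1)Cc1ccc(Nc2ncnc3ccc(Br)cc23)cc1`) keeps the bromo of compound 3 and changes the other end of the molecule: 4-bromophenyl in place of 3,4-dichlorophenyl on a double-bonded chain carbon bound to a double-bonded chain carbon. The 4-bromophenyl group takes the place of 3,4-dichlorophenyl on a double-bonded chain carbon bound to a double-bonded chain carbon.

The same exchange has been measured only once, without the bromo, as an at least 2.4-fold higher number from compound 1 to compound 2 (0.38 log units; beyond the scatter). From the compounds shown here alone, that single step rests on a limit, so its full size is unknown, and its transfer to the bromo-bearing pair is untested. A rise in this assay beyond the scatter is therefore expected, of at least modest size. The expected change is a 4.0-fold higher number from compound 3 to compound 4 (0.60 log units; beyond the scatter). For compound 4 the estimated value is 20000 nM, with an expected range from 8000 nM to 70000 nM.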

Compound 4, concentration for 50% growth inhibition: > 100000 nM
Compound 4 was reported as a limit; the forecaster's own chance of this, stated with the estimate: 15%; middle value at least 5.0-fold (0.69 log units) away from the limit.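

The exchange of 3,4-dichlorophenyl for 4-bromophenyl now has a reading on the bromo-bearing core in this assay, an at least 20-fold higher number from compound 3 to compound 4 (1.30 log units; beyond the scatter), so the lower number of compound 3 does not carry over to compound 4. Set against the pair without the bromo, the size of the exchange on the two cores cannot be told apart: the same change on two cores in this assay, an at least 2.4-fold higher number (0.38 log units; beyond the scatter) from compound 1 to compound 2 and an at least 20-fold higher number (1.30 log units; beyond the scatter) from compound 3 to compound 4; the limit leaves it open whether they differ. Going by these compounds alone, compound 4 is recorded at a limit, as is compound 2, so the step between them cannot be read and the lower number that goes with the bromo is seen only with 3,4-dichlorophenyl in place: the limit of > 100000 nM in this assay, at which 2 of the 4 values shown sit.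

The compounds shown leave open which of the two chlorines of 3,4-dichlorophenyl goes with the lower numbers, and how a 4-chlorophenyl group would read on the bromo-bearing core. Also open, from the compounds shown here alone, is whether another group on the same aromatic carbon as the bromo, such as a methoxy or an amine, would give a lower number than compound 3 does.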